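Ring Size Swap on a Shared Core: Expecting Compound 4

This account rests on a few compounds, and the source may have more. Where it says the series, first, only, none or still open, it means among the compounds named here.

Compound 1, `O=c1sc2cc(NS(=O)(=O)c3ccccc3)ccc2n1CCN1CCCC1`, gives 11% in an assay on HEK293 cells for displacement of a labelled ligand from 5-hydroxytryptamine receptor 6 (Homo sapiens), read by radioligand binding, with a stated time of 60 min, tested at 100 nM; on this read-out higher numbers stand for more inhibition at the one concentration tested (going by the name of the read-out) and lower numbers for less inhibition.
Compound 2, `O=c1sc2cc(NS(=O)(=O)c3ccccc3)ccc2n1CCN1CCCCC1`, gives 6%.
Compound 3, `CN(c1cccc2ccccc12)S(=O)(=O)c1ccc2c(c1)sc(=O)n2CCN1CCCC1`, gives 40%.

Compound 1 and compound 2 differ in one place only: piperidin-1-yl in place of pyrrolidin-1-yl on a saturated chain carbon, two bonds along the chain from an aromatic nitrogen. The step measured for that change is a number 5 percentage points lower from compound 1 to compound 2 (within the scatter). Compound 3 stands highest of the three; how its core differs from that of compound 1 is not broken down here.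

Compound 4, `CN(c1cccc2ccccc12)S(=O)(=O)c1ccc2c(c1)sc(=O)n2CCN1CCCCC1`, has not yet been measured. It differs from compound 3 by piperidin-1-yl in place of pyrrolidin-1-yl on a saturated chain carbon, two bonds along the chain from an aromatic nitrogen, the same change as between compound 1 and compound 2, made at the same place. The expected step is a number 5 percentage points lower from compound 3 to compound 4 (within the scatter), resting on the earlier measured step of a number 5 percentage points lower from compound 1 to compound 2 (within the scatter), which stayed within the usual scatter. Compound 4 is therefore expected to give about 35%, estimated to lie between 20% and 50%.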

Compound 4, a percentage reported as inhibition, at one concentration (the size of the read-out at that concentration, not a potency): 14%
The estimate for compound 4 lay 21 percentage points above the measured number; the whole stated range lies above it.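

On the core of compound 3, putting piperidin-1-yl in place of pyrrolidin-1-yl gives a number 26 percentage points lower from compound 3 to compound 4 (beyond the scatter) in this assay. Among these compounds, the size of the step therefore did not carry over from one core to the other: the same change on two cores in this assay, a number 5 percentage points lower (within the scatter) from compound 1 to compound 2 and a number 26 percentage points lower (beyond the scatter) from compound 3 to compound 4, 21 percentage points apart, beyond the scatter of two such steps This shows that the effect of this ring swap depends on the core that carries it, but with only two pairs, it does not show which difference between the cores matters, or why.

The compounds shown leave open how a dimethylamino group, a morpholin-4-yl group or a longer chain would behave on these two cores. As far as these compounds go, whether a third core would follow either step also remains open.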